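Moving the Methoxy Group Across Two Related Cores

A few compounds are considered here, and "the series" means these few. Any claim that something is new, unique, unknown or untested is made for them only; others in the source may bear on it.

Compound 1 `COc1ccccc1NC(=O)Nc1cccc(CNc2ncnc3ccccc23)c1` was examined in a functional assay on HepG2 cells (Homo sapiens) for antiproliferative activity, read by MTT assay (a lower number here means a stronger inhibitor, a higher number a weaker inhibitor), where compound 1 gives 17500 nM. Compound 2 `COc1ccc(NC(=O)Nc2cccc(CNc3ncnc4ccccc34)c2)cc1` differs from it by 4-methoxyphenyl in place of 2-methoxyphenyl on an amide-type nitrogen. In this assay compound 2 reaches only a limit, > 50000 nM. The resulting step, an at least 2.8-fold higher number from compound 1 to compound 2 (0.45 log units; beyond the scatter), is known only as a bound because of the limit of > 50000 nM in this assay, at which 1 of the 3 values shown sits.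

Compound 3 `COc1ccccc1NC(=O)Nc1cccc(CNc2ncnc3cc(OC)c(OC)cc23)c1` is built on a different core; how the two cores differ is not broken down here. In this assay compound 3 gives 27200 nM, and this value and that of compound 1 lie within the usual scatter of each other, so nothing can be said about their order.

Compound 4 `COc1ccc(NC(=O)Nc2cccc(CNc3ncnc4cc(OC)c(OC)cc34)c2)cc1` has not yet been measured in this assay. It stands to compound 3 as compound 2 stands to compound 1: the change is 4-methoxyphenyl in place of 2-methoxyphenyl on an amide-type nitrogen, and the surroundings of the place are the same word for word in both pairs, so this is the same change made a second time.

For compound 4 the expected step is a 2.6-fold higher number from compound 3 to compound 4 (0.41 log units; beyond the scatter), placed beside the earlier step of an at least 2.8-fold higher number from compound 1 to compound 2 (0.45 log units; beyond the scatter). This expectation rests on compound 3 starting from 27200 nM, so that a step of the earlier size would carry it to the edge of what the assay reports. Compound 4 is therefore estimated at 70000 nM, within a range from 35000 nM to 150000 nM, with a real chance that only a limit is reported.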

Compound 4, half-maximal inhibitory concentration: > 50000 nM
Compound 4 ended at the assay's limit; the forecaster's own chance of this, stated with the estimate: 65%; the middle value lies beyond the limit too.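

In this assay compound 4 reaches only a limit of the assay, > 50000 nM, and not a measured number. Replacing 2-methoxyphenyl with 4-methoxyphenyl on the amide-type nitrogen of this second core gives an at least 1.8-fold higher number from compound 3 to compound 4 (0.26 log units; that floor lies within the scatter), so the floor alone does not establish a real shift on this core, although the true step may be larger. The result is compatible with the change carrying over from one core to the other, since the 4-methoxyphenyl compound ends at the limit on both, but it shows neither that the two steps are the same size nor that they differ: the same change on two cores in this assay, an at least 2.8-fold higher number (0.45 log units; beyond the scatter) from compound 1 to compound 2 and an at least 1.8-fold higher number (0.26 log units; that floor lies within the scatter) from compound 3 to compound 4; the limit leaves it open whether they differ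

How far the true values of compound 2 and compound 4 lie past the limit remains open, and so does any finer comparison of the two cores: the limit of > 50000 nM in this assay, at which 2 of the 4 values shown sit. The compounds shown also leave open whether the course seen with the methoxy group would hold on either core for a phenyl ring carrying an amine or a carboxylic acid instead.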